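The source may report more compounds than this note shows. Statements on the series, on what has been measured and on what is new or still open speak of the compounds shown alone.

Two hydrazone-linked compounds built on the same core were tested in a functional assay on DU-145 cells (Homo sapiens) for cytotoxicity; a higher number here means a weaker inhibitor, a lower number a stronger inhibitor. Compound 1 `COc1ccc(Cn2cc(/C=N\NC(=O)c3c[nH]c4ccccc34)c3ccccc32)cc1` gives 43900 nM in this assay. Compound 2 `Cn1cc(C(=O)N/N=C\c2cn(Cc3ccc(Cl)cc3)c3cc(F)ccc23)c2ccccc21` differs from compound 1 in several places at once. In this assay compound 2 gives 84200 nM. Among the compounds with values here, these two numbers lie within the usual scatter of repeated measurements of each other, so they show no difference between the compounds that can be relied on.

Compound 3 `O=C(N/N=C\c1cn(Cc2ccc(Cl)cc2)c2ccccc12)c1c[nH]c2ccccc12` has not yet been measured in this assay. It differs from compound 1 in one place: chloro in place of methoxy on an aromatic carbon. Within the data shown here, no measured pair differs by exactly this change, so nothing tells directly how large its effect will be. Among the measured compounds shown here, the only guide is compound 2, which also carries the chlorobenzyl group together with other changes and gives 84200 nM, a number within the scatter of compound 1. On that basis the step from compound 1 to compound 3 is expected to be a 1.1-fold higher number from compound 1 to compound 3 (0.06 log units; within the scatter), no larger than the scatter in either direction. Compound 3 is therefore estimated to give 50000 nM in this assay, with a likely range from 20000 nM to 125000 nM.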

Compound 3, half-maximal inhibitory concentration: 52100 nM
Compound 3: the middle estimate sits 1.0-fold (0.02 log units) below what was measured; low and high end bracket the measured number.
By their numbers in this assay, from the lowest: compounds 1, 3 and 2 (each within the scatter of the next).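

Within the data shown here, replacing the 4-methoxybenzyl group with a 4-chlorobenzyl group gives the first comparison in this assay that changes only one place, and it comes out as a 1.2-fold higher number from compound 1 to compound 3 (0.07 log units; within the scatter). At this position, on an aromatic carbon para to a large group, methoxy and chloro therefore cannot be told apart by this read-out, even though methoxy carries a hydrogen-bond acceptor and chloro does not. Nothing measured here bears on why the two groups read so closely.

Still open, going by these compounds, is whether the number at this position would move beyond the scatter with a very different group there, such as an amine, a carboxylic acid or a longer chain in place of methoxy. On these data alone, it is also open whether the swap from methoxy to chloro would read the same with the other parts of compound 2 in place, or with the group on another carbon of that ring.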